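The source may hold more compounds than are shown below. What is called first, only, known or untested is meant among the compounds shown, and "the series" means these compounds.

Compound 1, `O=c1c(SC(=S)N2CCCC2)coc2ccc(Cl)cc12`, in a functional assay on MCF7 cells (Homo sapiens) for antiproliferative activity, read by MTT assay, with a stated time of 72 h (on this read-out higher numbers stand for weaker inhibition and lower numbers for stronger inhibition), gives > 25000 nM.
Compound 2, `O=c1cc(CSC(=S)N2CCCCC2)oc2cc(Cl)ccc12`, in this assay gives > 25000 nM.
Compound 3, `O=c1cc(CSC(=S)N2CCCC2)oc2cc(Cl)ccc12`, in this assay gives > 25000 nM.

Each of these three values is a limit of the assay and not a number; all of them sit at the limit of > 25000 nM in this assay, at which 3 of the 3 values shown sit. Compound 3 and compound 2 differ by piperidin-1-yl in place of pyrrolidin-1-yl on a thiocarbonyl carbon, and the step that the two limits leave unreadable from compound 3 to compound 2 cannot be sized, since two limits bound it on either side. Compound 1 and compound 3 differ in more than one place, and the difference between their two cores is not broken down here.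

Compound 4, `O=c1c(SC(=S)N2CCCCC2)coc2ccc(Cl)cc12`, has not yet been measured. It differs from compound 1 by piperidin-1-yl in place of pyrrolidin-1-yl on a thiocarbonyl carbon, the same change that turns compound 3 into compound 2. The expectation for compound 4 rests on compound 1 standing at the limit of > 25000 nM in this assay, at which 3 of the 3 values shown sit, and on the same change leaving compound 2 and compound 3 at that limit. Compound 4 is therefore expected in this assay to give about 40000 nM, between 12000 nM and 150000 nM, most probably reported as a limit once more. The step that the limit leaves unreadable from compound 1 to compound 4 is expected to be essentially flat.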

Compound 4, half-maximal inhibitory concentration: > 25000 nM
Compound 4 was reported as a limit; the forecaster's own chance of this, stated with the estimate: 85%; the middle value does not contradict the limit.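

In this assay compound 4 gives > 25000 nM, which is a limit and not a number. Compound 1 also stands at a limit, so no step can be read between compound 1 and compound 4: the limit of > 25000 nM in this assay, at which 4 of the 4 values shown sit.

The compounds shown leave open what numerical potency any of them has, and whether piperidin-1-yl and pyrrolidin-1-yl differ at all in this assay.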